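The source may hold more compounds than are shown below. What is called first, only, known or untested is meant among the compounds shown, and "the series" means these compounds.

In an ADME assay on MT4 cells (Homo sapiens) for cytotoxicity (on this read-out higher numbers stand for lower toxicity in this test and lower numbers for higher toxicity in this test), compound 1 (`O=c1[nH]c2ccc(Cl)cc2n1Cc1c(F)cccc1F`) reads > 424000 nM and this is a limit, not a number. Within the data shown here, compound 2 (`O=c1[nH]c2ccc(Cl)cc2n1S(=O)(=O)c1c(F)cccc1F`) gives 194000 nM as a measured number, the only one so far, and the expectation below rests on it. Compound 3 (`CC(=O)n1c(=O)n(Cc2c(F)cccc2F)c2cc(Cl)ccc21`) keeps the core of compound 1 and has acetyl in place of hydrogen on an aromatic nitrogen. Among the measured compounds shown here, no measured step in this assay covers this change, so the forecast is loose. A modest move toward lower numbers is expected, which would mean higher toxicity in this test, and a reading that again stops at a limit remains quite possible. The estimated step is an at least 1.5-fold lower number from compound 1 to compound 3 (0.18 log units; that floor lies within the scatter) and it is expected to be small. Compound 3 is expected at 280000 nM with an estimated range from 90000 nM to 450000 nM in the coming measurement.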

Compound 3, half-maximal cytotoxic concentration: > 5950 nM
Compound 3: no number, only a limit; the forecaster's own chance of this, stated with the estimate: 50%; the middle value is on the limit's open side.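

Compound 1 reads > 424000 nM in this assay, which is a limit. Compound 3 reads > 5950 nM, also a limit, so no step can be read between compound 1 and compound 3. The compounds shown leave open whether and how far acetyl in place of hydrogen on an aromatic nitrogen moves the number in this assay.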